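Replacing Isopropyl with a Halogenated Aryl in the Solubility Series

The source may hold more compounds than are shown below. What is called first, only, known or untested is meant among the compounds shown, and "the series" means these compounds.

Of the compounds shown here, three carrying the same core have been measured in a physicochemical assay for solubility, with a stated time of 18 h, at pH 7.4; a lower number here means a less soluble compound, a higher number a more soluble compound. Compound 1 `COc1cccc(CNCCCNc2ccnc3cc(Oc4ccccc4)ccc23)c1O` gives 14500 nM, and compound 3 `COc1ccc(Oc2ccc3c(NCCCNCc4cccc(OC)c4O)ccnc3c2)cc1` gives 14500 nM; the step of no change at the digits printed from compound 1 to compound 3 (within the scatter). Compound 2 `CC(C)Cc1ccc2c(NCCCNCc3ccco3)ccnc2c1` gives 4200 nM, the lowest of the three numbers and beyond the scatter from both others.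

Compound 4 `Fc1ccc(Cc2ccc3c(NCCCNCc4ccco4)ccnc3c2)c(Cl)c1` differs from compound 2 by 2-chloro-4-fluorophenyl in place of isopropyl on a saturated chain carbon bound to an aromatic carbon. Going by the values given here, no measured step concerns this kind of change; the only step on record, from compound 1 to compound 3, involved a different group and showed nothing beyond the scatter. Starting from the lowest value in the set, compound 4 is expected to fall modestly, the step of a 2.3-fold lower number from compound 2 to compound 4 (0.37 log units; beyond the scatter) being the estimate. Compound 4 is thus estimated at 1800 nM, between 400 nM and 6000 nM.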

Compound 4, solubility: 4200 nM
Estimate against measurement, compound 4: 2.3-fold (0.37 log units) below, within the range that was stated.
By their numbers in this assay, from the lowest: compounds 2 and 4 (each within the scatter of the next); then compounds 1 and 3 (each within the scatter of the next).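

In this assay, going by these compounds alone, the step at this position reads no change at the digits printed from compound 2 to compound 4 (within the scatter), the first measurement of any change on a saturated chain carbon bound to an aromatic carbon. Within the data shown here, the only earlier step concerned methoxy on an aromatic carbon, so the compounds before this one said nothing about this place. Here, a group of 8 heavy atoms with a six-membered aromatic ring replaced one of 3 carbons, and the read-out did not separate the pair. No supporting measurement accounts for this result.

As far as these compounds go, whether an amine or a carboxylic acid at this position would give a different number remains open.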